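Cytotoxicity notes on a vinyl amide series

A few compounds are considered here, and "the series" means these few. Any claim that something is new, unique, unknown or untested is made for them only; others in the source may bear on it.

The series rests on one shared core carrying an amide with a vinyl group and an aromatic amino substituent. Compound 1 `C=CC(=O)Nc1cccc(Oc2nc(Nc3ccn(C)n3)nc3c2CSCC3)c1` is the parent. Compound 2 `C/C=C/C(=O)Nc1cccc(Oc2nc(Nc3ccn(C)n3)nc3c2CSCC3)c1` and compound 3 `C=CC(=O)Nc1cccc(Oc2nc(Nc3ccc(OC)cc3)nc3c2CSCC3)c1` each change it in one place, and compound 4 `C/C=C/C(=O)Nc1cccc(Oc2nc(Nc3ccc(OC)cc3)nc3c2CSCC3)c1` carries both changes together; compound 4 has not yet been measured.

In an ADME assay on L02 cells (Homo sapiens) for cytotoxicity, read by MTT assay, with a stated time of 72 h (a lower number here means a stronger inhibitor, a higher number a weaker inhibitor), compound 1 gives > 50000 nM, which is a limit of the assay and not a number. In this assay compound 2 gives > 50000 nM, also a limit. In this assay compound 3 gives > 50000 nM, again a limit.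

The change from compound 1 to compound 2 is prop-1-en-1-yl in place of vinyl on a carbonyl carbon. Its step is a step that the two limits leave unreadable from compound 1 to compound 2. The core of compound 3 differs from that of compound 1 by 4-methoxyphenyl in place of 1-methyl-1H-pyrazol-3-yl on a nitrogen on an aromatic ring, and the step that the two limits leave unreadable from compound 1 to compound 3 is unreadable in the same way. All three values sit at the limit of > 50000 nM in this assay, at which 3 of the 3 values shown sit.

The change from compound 3 to compound 4 is prop-1-en-1-yl in place of vinyl on a carbonyl carbon, the same change as from compound 1 to compound 2, at a place described in identical words. The expected step is a step that the limit leaves unreadable from compound 3 to compound 4, which rests on compound 1 and compound 2 both sitting at the limit of > 50000 nM in this assay, at which 3 of the 3 values shown sit. Compound 4 is expected to give 60000 nM in this assay, most probably reported once more as a limit rather than a number, with an estimated range from 30000 nM to 150000 nM.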

Compound 4, half-maximal inhibitory concentration: > 50000 nM
Compound 4: a limit, no number; the forecaster's own chance of this, stated with the estimate: 90%; the middle value lies beyond the limit too.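

No step can be read from compound 3 or compound 2 to compound 4, since in this assay compound 4, like the other compounds, gives a limit and not a number: the limit of > 50000 nM in this assay, at which 4 of the 4 values shown sit.

The compounds shown leave open where any of the four would fall as an actual number in this assay, and whether either change, alone or combined, shifts that number at all.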